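From benzyl to isopropyl on an amine nitrogen

The source may report more compounds than this note shows. Statements on the series, on what has been measured and on what is new or still open speak of the compounds shown alone.

Of the compounds shown here, two have numbers so far in a physicochemical assay for lipophilicity, read by HPLC, using the shake flask method; on this read-out lower numbers stand for lower lipophilicity and higher numbers for higher lipophilicity. Compound 1 (`CCCCCN(Cc1ccc(Cl)nc1)/C(C)=N/C#N`) gives 2.37, and compound 2 (`C/C(=N\C#N)N(Cc1ccccc1)Cc1ccc(Cl)nc1`) gives 2.11, so compound 2 stands within the usual scatter of compound 1. The unmeasured compound 3 (`C/C(=N\C#N)N(Cc1ccc(Cl)nc1)C(C)C`) keeps the rest of compound 2 and alters one group: isopropyl in place of benzyl on an amine nitrogen. In words, isopropyl takes the place of benzyl on an amine nitrogen, and the ring leaves with the benzyl.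

Among the measured compounds shown here, only one measured step bears on this change: a number 0.26 log units lower from compound 1 to compound 2 (within the scatter). That step also altered a group on the amine nitrogen, but it stayed within the scatter and shows no clear trend. It swapped one sizeable group for another, whereas here a smaller group replaces a larger one, with no ring in its place. A lower number, beyond the scatter, is therefore expected, though a single step offers thin support. The estimated change in this assay is a number 0.51 log units lower from compound 2 to compound 3 (beyond the scatter). Compound 3 is expected at 1.6, with an estimated range from 1.25 to 1.95.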

Compound 3, partition coefficient: 1.46
For compound 3 the middle estimate is 0.14 log units above the measured one; the measured number falls inside the stated range.
By their numbers in this assay, from the lowest: compound 3; then compounds 2 and 1 (each within the scatter of the next).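

In this assay, this place on the amine nitrogen can clearly shift the number: isopropyl in place of benzyl gives a number 0.65 log units lower from compound 2 to compound 3 (beyond the scatter), and isopropyl in place of pentyl gives a number 0.91 log units lower from compound 1 to compound 3 (beyond the scatter), whereas the earlier step between compound 1 and compound 2 stayed within the scatter. Pentyl carries no ring, so the fall seen on replacing it shows that losing the aromatic ring of benzyl is not needed for a drop of this kind among these three compounds. No independent data here explain why the number falls with this change.

Isopropyl differs from pentyl in both chain length and branching, so these two compounds cannot separate those features, and a straight propyl chain would be needed to tell them apart. On these data alone, it also remains open whether a still smaller methyl or ethyl group would sit lower again, and how a chain ending in a hydroxyl group or an amine would read at this same place.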